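Adding a fluoro group to compound 2

This account rests on a few compounds, and the source may have more. Where it says the series, first, only, none or still open, it means among the compounds named here.

Values from an ADME assay on THP-1 cells (Homo sapiens) for cytotoxicity, read by flow cytometry and propidium iodide staining, with a stated time of 72 h (a higher number here means a weaker inhibitor, a lower number a stronger inhibitor), follow
compound 1 `COc1c(-c2ccccc2F)oc2ccc(NC(C)=O)cc2c1=O` gives > 125000 nM (a limit)
compound 2 `COc1c(-c2ccccc2)oc2ccc(N)cc2c1=O` gives 74000 nM (a number)

The value of compound 1 is a limit of the assay and not a number. For the measured compounds named here, compound 2 at 74000 nM therefore holds the only true number so far. Compound 3 `COc1c(-c2ccccc2F)oc2ccc(N)cc2c1=O` differs from compound 2 by fluoro in place of hydrogen on an aromatic carbon and in words that is fluoro in place of hydrogen on an aromatic carbon. Going by the values given here, no measured step shows this change, so nothing beyond the usual scatter is expected in this assay here. A step of a 1.1-fold higher number from compound 2 to compound 3 (0.03 log units; within the scatter) is expected. Compound 3 is estimated at 80000 nM with a range from 40000 nM to 125000 nM expected.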

Compound 3, half-maximal inhibitory concentration: > 125000 nM
Compound 3 ended at the assay's limit; the forecaster's own chance of this, stated with the estimate: 25%; at least 1.5-fold (0.19 log units) between middle value and limit.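

In this assay, for the compounds shown here, the first measured change at this place on the ring, phenyl to 2-fluorophenyl, gives an at least 1.6-fold higher number from compound 2 to compound 3 (0.22 log units; that floor lies within the scatter), so the floor of this step does not clear the scatter, although the true step could be larger. On these data alone, compound 3 sits at a limit of the assay and not at a number, so the true size of the step stays unknown because of where that limit lies: the limit of > 125000 nM in this assay, at which 2 of the 3 values shown sit. The step that swaps acetyl on the nitrogen for hydrogen cannot be read, as both of its ends are limits.

As far as these compounds go, whether a chloro or methoxy group on this aromatic carbon, ortho to a large group, would give a true number stays open. Also open, from the compounds shown here alone, is what acetyl on the nitrogen does when the plain phenyl is kept.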